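A few compounds are considered here, and "the series" means these few. Any claim that something is new, unique, unknown or untested is made for them only; others in the source may bear on it.

In an assay for inhibition of Caspase-8 (Homo sapiens) (on this read-out higher numbers stand for weaker inhibition and lower numbers for stronger inhibition), three compounds of one series have been measured so far. Compound 2 `CCC(C(=O)N[C@@H](CC(=O)O)C(=O)CNCN1CCCC1)n1ccnc(NCc2nonc2C)c1=O` gives 6220 nM, the highest of the three numbers. Compound 1 `CCC(C(=O)N[C@@H](CC(=O)O)C(=O)CSCc1ccccc1)n1ccnc(NCc2cccs2)c1=O` gives 2090 nM, and compound 3 `CCC(C(=O)N[C@H](C=O)CC(=O)O)n1ccnc(NCc2nonc2C)c1=O` gives 990 nM. Within the data shown here, the only step between two of them that differs in a single place runs from compound 2 to compound 3, where the whole chain on the carbonyl carbon is cut away: a 6.3-fold lower number from compound 2 to compound 3 (0.80 log units; beyond the scatter).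

Compound 4 `CCC(C(=O)N[C@@H](CC(=O)O)C(=O)CNCN1CCc2ccccc2C1)n1ccnc(NCc2nonc2C)c1=O` differs from compound 2 in one place: 1,2,3,4-tetrahydroisoquinolin-2-yl in place of pyrrolidin-1-yl on a saturated chain carbon bound to an amine nitrogen. Among the measured compounds shown here, no measured pair shows this exchange of one ring for another. The step from compound 2 to compound 3 removes the chain entirely rather than altering the ring at its end, so it bears on the question only loosely, and compound 1 carries both a different chain and a different group on the shared core, so its value cannot be tied to this change alone. On that basis only a small move is expected in this assay, with no firm direction: a 1.2-fold lower number from compound 2 to compound 4 (0.09 log units; within the scatter). Compound 4 is therefore estimated at 5000 nM, within an expected range from 1500 nM to 16000 nM.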

Compound 4, half-maximal inhibitory concentration: 7380 nM
The estimate for compound 4 lay 1.5-fold (0.17 log units) below the measured number, and the stated range covers the measured number.
By their numbers in this assay, from the lowest: compound 3; then compound 1; then compounds 2 and 4 (each within the scatter of the next).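

In this assay, replacing pyrrolidin-1-yl with 1,2,3,4-tetrahydroisoquinolin-2-yl on a saturated chain carbon bound to an amine nitrogen gives a 1.2-fold higher number from compound 2 to compound 4 (0.07 log units; within the scatter), so the end of this chain can take a second ring, a six-membered aromatic ring of carbon only, with no change that can be told from the scatter of repeated measurements. The earlier step, a 6.3-fold lower number from compound 2 to compound 3 (0.80 log units; beyond the scatter), showed only that cutting away the whole chain on the carbonyl carbon matters, whereas this pair shows that in these two compounds the ring at the chain's end can be exchanged without a readable effect on the number. Nothing available here accounts for this lack of change.

The compounds shown leave open whether this tolerance extends to other groups at the same place, such as a morpholine ring, a piperidine ring or an open-chain dimethylamino group. They also leave open whether a carboxylic acid or a methoxy group on the aromatic ring of the 1,2,3,4-tetrahydroisoquinolin-2-yl group would move the number in either direction.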